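The source may report more compounds than this note shows. Statements on the series, on what has been measured and on what is new or still open speak of the compounds shown alone.

In a functional assay on HT cells (Homo sapiens) for antiproliferative activity, read by fluorescence, with a stated time of 72 h (on this read-out lower numbers stand for stronger inhibition of growth and higher numbers for weaker inhibition of growth), compound 1 `CC(O)CSc1nc(NCc2ccc(-c3ccccn3)cc2)c2[nH]nc(C(C)C)c2n1` reads 62 nM and compound 2 `CC(C)c1n[nH]c2c(NCc3ccc(-c4ccccn4)cc3)nc(SCCN)nc12` reads 22 nM on the same core. Compound 3 `CC(C)c1n[nH]c2c(NCc3ccc(-c4ccccn4)cc3)nc(SCCCN)nc12` reads 120 nM and so stands level with compound 1 within the scatter, the step being a 1.9-fold higher number from compound 1 to compound 3 (0.29 log units; within the scatter) and no more. It stands clearly apart only from compound 2, with a 5.5-fold higher number from compound 2 to compound 3 (0.74 log units; beyond the scatter) as the gap.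

Compound 4 `CC(C)c1n[nH]c2c(NCc3ccc(-c4ccccn4)cc3)nc(SCCn3ccnc3)nc12` follows from compound 3 by 1H-imidazol-1-yl in place of aminomethyl on a saturated chain carbon, two bonds along the chain from a sulfur and the rest of the structure stays the same. Cut further out, (3-aminopropyl)sulfanyl gives way to (2-(1H-imidazol-1-yl)ethyl)sulfanyl.

Among the compounds with values here, no measured step brings a ring onto this chain, so the evidence is indirect. The changes at this chain end so far are a 2.8-fold lower number from compound 1 to compound 2 (0.45 log units; beyond the scatter) and a 5.5-fold higher number from compound 2 to compound 3 (0.74 log units; beyond the scatter) as modest moves, alongside the step within the scatter already noted. Nothing in this set points to a large change in this assay for compound 4. Within the data shown here, a small move toward a lower number is expected, probably not beyond the scatter, and the lean rests only on compound 2 at 22 nM as the one value clearly apart from compound 3. The estimated shift is a 1.5-fold lower number from compound 3 to compound 4 (0.18 log units; within the scatter) in this reading. For compound 4 the estimate is 80 nM within an expected range of 25 nM to 250 nM as a working figure.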

Compound 4, concentration for 50% growth inhibition: 155 nM
Estimate against measurement, compound 4: 1.9-fold (0.29 log units) below; the range from low to high includes it.
By their numbers in this assay, from the lowest: compound 2; then compounds 1, 3 and 4 (each within the scatter of the next, the first and the last beyond it).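

In this assay, the first ring at this chain end, 1H-imidazol-1-yl in place of aminomethyl on a saturated chain carbon, two bonds along the chain from a sulfur, gives a 1.3-fold higher number from compound 3 to compound 4 (0.11 log units; within the scatter), so at this place the swap of an open amine end for an aromatic ring with 0 hydrogen-bond donors leaves the read-out level with that of compound 3. Compound 2 stays the strongest of the set, with a 7.0-fold higher number from compound 2 to compound 4 (0.85 log units; beyond the scatter), and a 2.5-fold higher number from compound 1 to compound 4 (0.40 log units; beyond the scatter) now opens a gap beyond the scatter, where the gap from compound 1 to compound 3 lay within it, so the hydroxyl-bearing chain of compound 1 and the ring-bearing chain of compound 4 can be told apart. No measured property in the data accounts for any of these steps.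

The compounds shown leave open whether the edge of compound 2 belongs to its free amino end or to its shorter chain, and a dimethylamino group on the same chain would speak to that. Also open, on these data alone, is how a carboxylic acid at the chain end, or a longer chain carrying 1H-imidazol-1-yl, would read against compound 4.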